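Benzyl ether variation on the shared core

The source may hold more compounds than are shown below. What is called first, only, known or untested is meant among the compounds shown, and "the series" means these compounds.

Compound 2 `COc1cccc(OC)c1OCCNCCOc1ccccc1OCc1ccc(Cl)cc1` stands level with compound 1 `COc1cccc(OC)c1OCCNCCOc1ccccc1OCc1cccc(Cl)c1` at the low end of the three numbers in an assay on CHO cells for displacement of a labelled ligand from Alpha-1A adrenergic receptor (Homo sapiens); on this read-out lower numbers stand for stronger inhibition and higher numbers for weaker inhibition: compound 2 gives 0.251 nM and compound 1 gives 0.251 nM, while compound 3 `COc1cccc(OC)c1OCCNCCOc1ccccc1OCc1ccccc1[N+](=O)[O-]` gives 7.94 nM. Compound 4 `COc1cccc(COc2ccccc2OCCNCCOc2c(OC)cccc2OC)c1` carries 3-methoxyphenyl in place of 4-chlorophenyl on a saturated chain carbon bound to an oxygen on an aromatic ring. Two kinds of measured step bear on this. no change at the digits printed from compound 1 to compound 2 (within the scatter) shows that a different ring position for the chlorine costs nothing, whereas a 32-fold higher number from compound 2 to compound 3 (1.50 log units; beyond the scatter) and a 32-fold higher number from compound 1 to compound 3 (1.50 log units; beyond the scatter) show that a different substituent on this ring can cost a great deal. A methoxy group fits neither case exactly, so a modest loss is expected, a 2.4-fold higher number from compound 2 to compound 4 (0.38 log units; beyond the scatter). For compound 4 in this assay the estimate is 0.6 nM, with a range from 0.15 nM to 2.5 nM.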

Compound 4, inhibition constant: 2 nM
For compound 4 the middle estimate is 3.3-fold (0.52 log units) below the measured one, and the stated range covers the measured number.
By their numbers in this assay, from the lowest: compounds 1 and 2 (each within the scatter of the next); then compound 4; then compound 3.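

In this assay methoxy in place of chloro on an aromatic carbon gives an 8.0-fold higher number from compound 1 to compound 4 (0.90 log units; beyond the scatter) and 3-methoxyphenyl in place of 4-chlorophenyl gives an 8.0-fold higher number from compound 2 to compound 4 (0.90 log units; beyond the scatter), so the tolerance seen for moving the chlorine does not extend to exchanging it for methoxy. Yet 3-methoxyphenyl in place of 2-nitrophenyl gives a 4.0-fold lower number from compound 3 to compound 4 (0.60 log units; beyond the scatter), which sets a third, intermediate level at this position. No evidence here accounts for this order.

From the compounds shown here alone, whether 3-methylphenyl or 3-trifluoromethylphenyl would stay level with the chlorophenyl pair remains open. So does the standing of 4-methoxyphenyl relative to compound 4.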